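The compounds below may be only part of what the source reports. "The series", "measured", "known", "first", "only" and "open" are said of these compounds alone.

In a functional assay on OVCAR-5 cells (Homo sapiens) for cytotoxicity, read by sulforhodamine B assay, with a stated time of 48 h, tested at 0.1 uM (a lower number here means a stronger effect, a higher number a weaker effect of the compound at the concentration tested), compound 2 `COc1cc(-c2cc(/C=C/C(=O)c3ccc(N)cc3)[nH]n2)cc(OC)c1OC` gives 103%, the highest of the two numbers recorded. Compound 1 `COc1ccc(-c2cc(/C=C/C(=O)c3ccc(N)cc3)[nH]n2)cc1` gives 95%, a reading lower by a gap that lies within the usual scatter, so the two compounds cannot be ranked against each other. Compound 3 `COc1cc(-c2cc(/C=C/C(=O)c3ccc(Cl)c(Cl)c3)[nH]n2)cc(OC)c1OC` has not yet been measured in this assay. It differs from compound 2 by 3,4-dichlorophenyl in place of 4-aminophenyl on a carbonyl carbon. For the measured compounds named here, no measured pair shows what this exchange does. Since both known numbers sit close together, the step from compound 2 to compound 3 is expected to be a number 8 percentage points lower from compound 2 to compound 3 (within the scatter), nothing beyond the scatter. Compound 3 is accordingly estimated at 95%, between 75% and 110%.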

Compound 3, a percentage reported as activity, at one concentration (the size of the read-out at that concentration, not a potency): 99%
Estimate against measurement, compound 3: 4 percentage points below; the range from low to high includes it.
By their numbers in this assay, from the lowest: compounds 1, 3 and 2 (each within the scatter of the next).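

In this assay, for the compounds shown here, the exchange of 4-aminophenyl for 3,4-dichlorophenyl on a carbonyl carbon gives a number 4 percentage points lower from compound 2 to compound 3 (within the scatter) and is the only measured step at this position. The two groups differ in their counts of hydrogen-bond donors and acceptors, yet the readings of the two compounds cannot be separated. Nothing measured here offers an explanation for this result.

From the compounds shown here alone, whether a carboxylic acid, a morpholine or a longer chain on this carbonyl carbon would give a reading beyond the scatter remains open. All these readings come from a single concentration and show only the size of the effect at that concentration.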